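The source may report more compounds than this note shows. Statements on the series, on what has been measured and on what is new or still open speak of the compounds shown alone.

Measured so far:

Compound 1, `Cc1nc(N)c2c(-c3cccs3)cn([C@@H]3O[C@H](CO)[C@@H](O)[C@H]3O)c2n1`: in a functional assay on A549 cells (Homo sapiens), read by MTT assay, with a stated time of 72 h (a higher number here means a weaker inhibitor, a lower number a stronger inhibitor), compound 1 gives > 20000 nM, which is a limit of the assay.
Compound 2, `Cc1nc(N)c2c(-c3cc4ccccc4o3)cn([C@@H]3O[C@H](CO)[C@@H](O)[C@H]3O)c2n1`: in this assay compound 2 gives > 20000 nM, again a limit.
Compound 3, `CN(C)c1ncnc2c1c(-c1cccs1)cn2[C@@H]1O[C@H](CO)[C@@H](O)[C@H]1O`: in this assay compound 3 gives > 20000 nM, also a limit.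

Compound 1 and compound 2 share a core and differ by 1-benzofuran-2-yl in place of thiophen-2-yl on an aromatic carbon. The step that the two limits leave unreadable from compound 1 to compound 2 cannot be read, since both ends sit at the limit of > 20000 nM in this assay, at which 3 of the 3 values shown sit. Compound 3 carries a different core; the difference between the core of compound 3 and that of compound 1 is not broken down here. All three values shown sit at the limit of > 20000 nM in this assay, at which 3 of the 3 values shown sit, so nothing measured so far separates any of these compounds from the others in this assay.

Compound 4, `CN(C)c1ncnc2c1c(-c1cc3ccccc3o1)cn2[C@@H]1O[C@H](CO)[C@@H](O)[C@H]1O`, has not yet been measured. It differs from compound 3 by 1-benzofuran-2-yl in place of thiophen-2-yl on an aromatic carbon. The place where the group sits is described in the same words for both pairs, so this is the same change as that from compound 1 to compound 2.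

For compound 4 the step that the limit leaves unreadable from compound 3 to compound 4 in this assay is expected to be unreadable in the same way, because compound 3 gives > 20000 nM and compound 2, carrying the same entering group, gives > 20000 nM. The estimate for compound 4 is therefore 40000 nM, with a range of 15000 nM to 150000 nM, and it is expected that only a limit will be reported.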

Compound 4, half-maximal inhibitory concentration: > 20000 nM
Compound 4 ended at the assay's limit; the forecaster's own chance of this, stated with the estimate: 85%; the middle value is on the limit's open side.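

In this assay compound 4 gives > 20000 nM, which is a limit of the assay. No step can be read from compound 3 to compound 4, since both ends sit at a limit: the limit of > 20000 nM in this assay, at which 4 of the 4 values shown sit.

The compounds shown leave open whether 1-benzofuran-2-yl in place of thiophen-2-yl changes potency at all in this assay, on either core.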